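Benzoxazolylthioethyl analogue of a trimethoxyphenyl anilide series

The source may hold more compounds than are shown below. What is called first, only, known or untested is meant among the compounds shown, and "the series" means these compounds.

Measured compounds:
compound 1, `COc1ccc(CN(C(=O)CSc2nc3ccc(OC)cc3s2)c2cc(OC)c(OC)c(OC)c2)cc1`, > 80000 nM
compound 2, `COc1ccc(CN(C(=O)CSc2ccccn2)c2cc(OC)c(OC)c(OC)c2)cc1`, 16000 nM
compound 3, `COc1ccc(CN(C(=O)CSc2nncs2)c2cc(OC)c(OC)c(OC)c2)cc1`, 9840 nM

In a functional assay on ECa-109 cells for antiproliferative activity against ECa-109 cell line (Homo sapiens), read by MTT assay, with a stated time of 48 h (on this read-out higher numbers stand for weaker inhibition and lower numbers for stronger inhibition), compound 1 gives > 80000 nM, which is a limit of the assay and not a number. Compound 2 gives 16000 nM and compound 3 gives 9840 nM in this assay. The two measured steps from compound 1 each exchange the 6-methoxy-1,3-benzothiazol-2-yl group on sulfur for a smaller heteroaryl: an at least 5.0-fold lower number from compound 1 to compound 2 (0.69 log units; beyond the scatter) and an at least 8.1-fold lower number from compound 1 to compound 3 (0.91 log units; beyond the scatter). Between compound 2 and compound 3 the step is a 1.6-fold lower number from compound 2 to compound 3 (0.21 log units; within the scatter).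

Compound 4, `COc1ccc(CN(C(=O)CCCSc2nc3ccccc3o2)c2cc(OC)c(OC)c(OC)c2)cc1`, differs from compound 1 in that (a group of 12 heavy atoms (9 carbon, 1 nitrogen, 1 oxygen, 1 sulfur; one five-membered aromatic ring with 2 hetero atoms, one six-membered aromatic ring of carbon only) in place of a group of 12 heavy atoms (8 carbon, 1 nitrogen, 1 oxygen, 2 sulfur; one five-membered aromatic ring with 2 hetero atoms, one six-membered aromatic ring of carbon only), on a saturated chain carbon bound to a carbonyl carbon). The entering group keeps a bicyclic heteroaryl on sulfur but drops the methoxy and adds the ethyl spacer, so the two measured steps bear on it only in part. Compound 1 stands at the limit (the limit of > 80000 nM in this assay, at which 1 of the 3 values shown sits), and compound 4 is expected to come off that limit with a step of an at least 2.2-fold lower number from compound 1 to compound 4 (0.35 log units; beyond the scatter). Compound 4 is therefore estimated at 35000 nM, within 10000 nM to 90000 nM.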

Compound 4, half-maximal inhibitory concentration: 11000 nM
Compound 4: middle estimate off by 3.2-fold (0.50 log units), on the high side; the measured number falls inside the stated range.
By their numbers in this assay, from the lowest: compounds 3, 4 and 2 (each within the scatter of the next). At a limit, above all of these: compound 1.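

In this assay, the entering 2-((1,3-benzoxazol-2-yl)sulfanyl)ethyl group gives an at least 7.2-fold lower number from compound 1 to compound 4 (0.86 log units; beyond the scatter), which shows that a group with a five-membered and a six-membered aromatic ring can also leave the limit at this place, as the pyridin-2-yl and 1,3,4-thiadiazol-2-yl groups had done. This group shows no separation from either of those: a 1.1-fold higher number from compound 3 to compound 4 (0.05 log units; within the scatter), and a 1.5-fold lower number from compound 2 to compound 4 (0.16 log units; within the scatter). The value for compound 1 remains a limit of the assay and not a number, so the first step has a bound only: the limit of > 80000 nM in this assay, at which 1 of the 4 values shown sits.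

The change to compound 4 swaps the ring system, drops the methoxy and adds the ethyl spacer in one step, so their separate shares stay unresolved. Also open, going by these compounds, is how a 1,3-benzoxazol-2-yl group directly on the sulfur, a longer chain or a terminal amine would read here.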